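Swapping Sulfo for Ethylsulfanyl on the Side Chain

A few compounds are considered here, and "the series" means these few. Any claim that something is new, unique, unknown or untested is made for them only; others in the source may bear on it.

In a functional assay on the whole organism with Rattus norvegicus as the target (on this read-out lower numbers stand for an effect already at smaller amounts and higher numbers for an effect only at larger amounts of compound), compound 1 `N#CCn1c(=N)sc2cc(OC(F)(F)F)ccc21` gives 3.5 mg/kg. For compound 2 `N=c1sc2cc(OC(F)(F)F)ccc2n1CCS(=O)(=O)O` the read-out is only a limit, > 10 mg/kg. Compound 3 `CCSCCn1c(=N)sc2cc(OC(F)(F)F)ccc21` carries ethylsulfanyl in place of sulfo on a saturated chain carbon, two bonds along the chain from an aromatic nitrogen. For the measured compounds named here, one measured step bears on this change: sulfomethyl in place of cyano gave an at least 2.8-fold higher number from compound 1 to compound 2 (0.45 log units; beyond the scatter). With the sulfo group gone, a move back towards smaller doses is expected. The expected step is an at least 2.5-fold lower number from compound 2 to compound 3 (0.39 log units; beyond the scatter). Compound 3 is estimated at 4 mg/kg, within a range of 1.5 mg/kg to 10 mg/kg.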

Compound 3, dose for half-maximal effect: 2.2 mg/kg
Compound 3: the middle estimate sits 1.8-fold (0.26 log units) above what was measured; measured number inside the range.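

In this assay, ethylsulfanyl on a saturated chain carbon, two bonds along the chain from an aromatic nitrogen, gives an at least 4.5-fold lower number from compound 2 to compound 3 (0.65 log units; beyond the scatter). Compound 2 stands only at a limit: the limit of > 10 mg/kg in this assay, at which 1 of the 3 values shown sits. Set against cyano, (ethylsulfanyl)methyl gives a 1.6-fold lower number from compound 1 to compound 3 (0.20 log units; within the scatter), so these two side chains cannot be told apart on this read-out, and the position accepts a sulfur-bearing chain without the shift seen with sulfo. The compounds shown leave open whether a carboxylic acid or an amine at this position would follow sulfo or ethylsulfanyl. They also leave open how a longer chain would fare.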